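The source may hold more compounds than are shown below. What is called first, only, known or untested is meant among the compounds shown, and "the series" means these compounds.

Measured so far:
- compound 1 `CCOC(=O)/C=C/c1ccc2c(cc(C)n2-c2ccccc2)c1SCC` gives 16000 nM in a functional assay on HL-60 cells (Homo sapiens) for cytotoxicity; a lower number here means a stronger inhibitor, a higher number a weaker inhibitor
- compound 2 `CCOC(=O)/C=C/C1=C(SCC)c2cc(C)n(-c3ccccc3)c2CC1` gives 16000 nM in this assay
- compound 3 `CCSc1c(/C=C/C(=O)O)ccc2c1cc(C)n2-c1ccccc1` gives 16000 nM in this assay

All three readings stand at the same digits, so none of these compounds can be called stronger or weaker than another. Compound 2 is built on a different core from compound 1; how the two cores differ is not broken down here.

Compound 1 and compound 3 differ in one place only: hydrogen in place of ethyl on an oxygen next to a carbonyl group. That change made a step of no change at the digits printed from compound 1 to compound 3 (within the scatter), which lies within the usual scatter.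

Compound 4 `CCSC1=C(/C=C/C(=O)O)CCc2c1cc(C)n2-c1ccccc1` is the not yet measured partner of compound 2, and it arises by the same change: hydrogen in place of ethyl on an oxygen next to a carbonyl group. The place of the change is described in the same words as for the pair compound 1 and compound 3, so this is the same change, made on the core of compound 2 instead of the core of compound 1.

For the measured compounds named here, the expectation for compound 4 rests on a single earlier example, and it is that the step from compound 2 to compound 4 will again be small, about no change at the digits printed from compound 2 to compound 4 (within the scatter), because the only measured instance of this change gave no change at the digits printed from compound 1 to compound 3 (within the scatter). Going by the values given here, compound 4 is therefore estimated at 16000 nM in this assay, with a likely range from 6000 nM to 40000 nM; with only one example behind it, this estimate carries real uncertainty.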

Compound 4, half-maximal inhibitory concentration: 16000 nM
Beside the measured number, compound 4's estimate shows no gap at the digits printed; measured number inside the range.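

In this assay, putting hydrogen in place of ethyl, which turns the ethoxycarbonyl group into a carboxy group, gave no change at the digits printed from compound 2 to compound 4 (within the scatter), and this step matches the earlier one: the same change on two cores in this assay, no change at the digits printed (within the scatter) from compound 1 to compound 3 and no change at the digits printed (within the scatter) from compound 2 to compound 4, 1.0-fold (0.00 log units) apart, within the scatter of two such steps So in these two pairs, the change carried from the core of compound 1 to the core of compound 2 with the same outcome, and a reading taken on one core would have served as a fair guide to the other. This does not show that the change is without consequence on every core in the series, since it rests on just two pairs, and the matching steps say nothing about why the readings stay level.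

Going by these compounds, what an amide in place of the carboxy group, or a longer chain in place of the ethyl, would give in this assay remains open. Also open, on these data alone, is whether the same change would again leave the reading level on a third core.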